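The compounds below may be only part of what the source reports. "The series", "measured", "known", "first", "only" and "open" are said of these compounds alone.

Series notes. In a functional assay on HepG2 cells (Homo sapiens) for antiproliferative activity, read by MTT assay, with a stated time of 48 h (on this read-out higher numbers stand for weaker inhibition and lower numbers for stronger inhibition), compound 1 `Cc1ccccc1-n1nncc1CN1C(=O)C2(C(C#N)=C(N)Oc3c2c2nc4ccccc4nc2c2ccccc32)c2ccccc21` reaches only a limit, > 50000 nM. Compound 2 `CCOc1ccc(-n2nncc2CN2C(=O)C3(C(C#N)=C(N)Oc4c3c3nc5ccccc5nc3c3ccccc43)c3ccccc32)cc1` likewise returns a limit in this assay, > 50000 nM. The step that the two limits leave unreadable from compound 1 to compound 2 is therefore not readable in size. Compound 1 and compound 2 both sit at a limit, (the limit of > 50000 nM in this assay, at which 2 of the 3 values shown sit). Within the data shown here, compound 3 `N#CC1=C(N)Oc2c(N)cc3nc4ccccc4nc3c2C12C(=O)N(Cc1cnnn1-c1ccccc1Cl)c1ccccc12` is the only member of the three with a number: in this assay compound 3 gives 33500 nM, weak inhibition, and it stands as the single measured value of the three. Compound 4 `Cc1ccc(-n2nncc2CN2C(=O)C3(C(C#N)=C(N)Oc4c(N)cc5nc6ccccc6nc5c43)c3ccccc32)cc1Cl` differs from compound 3 in one place, (3-chloro-4-methylphenyl in place of 2-chlorophenyl on an aromatic nitrogen). No measured step bears directly on this change: the only step shown, between compound 1 and compound 2, concerns a different pair of groups on that nitrogen and its size cannot be read from two limits. With nothing to carry over, no step beyond the scatter is expected, and compound 4 is expected to stay close to compound 3, as a 1.2-fold higher number from compound 3 to compound 4 (0.08 log units; within the scatter). The estimate for compound 4 in this assay is 40000 nM, with a range from 15000 nM to 100000 nM, and a fair chance that only a limit is returned.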

Compound 4, half-maximal inhibitory concentration: > 50000 nM
Compound 4 was reported as a limit (the forecaster's own chance of this, stated with the estimate: 45%); at least 1.2-fold (0.09 log units) between middle value and limit.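

In this assay, among these compounds, the step at this aromatic nitrogen can be read for the first time, though only as a floor: an at least 1.4-fold higher number from compound 3 to compound 4 (0.17 log units; that floor lies within the scatter). On these data alone, compound 4 returns only a limit, > 50000 nM, so the true size of the step remains unknown, and the exchange of 2-chlorophenyl for 3-chloro-4-methylphenyl cannot be said to exceed the usual scatter. With this result, compound 3 remains the only member with a number, and the other three compounds stand at the same limit: the limit of > 50000 nM in this assay, at which 3 of the 4 values shown sit.

As far as these compounds go, whether any group on this nitrogen gives stronger inhibition than compound 3 stays open. From the compounds shown here alone, it is also open whether an amine or a carboxylic acid on the phenyl ring would bring compound 4 back to a numerical value.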